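Longer alkyl groups on the ring nitrogen of a chromone chalcone

The compounds below may be only part of what the source reports. "The series", "measured", "known", "first", "only" and "open" are said of these compounds alone.

Three compounds share one core and differ only in the group on an aromatic nitrogen of a five-membered aromatic ring with 2 nitrogen. Compound 1 `Cn1ccnc1/C=C/C(=O)/C=C/c1coc2ccccc2c1=O` carries a methyl there, compound 2 `CCn1ccnc1/C=C/C(=O)/C=C/c1coc2ccccc2c1=O` an ethyl, and compound 3 `CC(C)n1ccnc1/C=C/C(=O)/C=C/c1coc2ccccc2c1=O` an isopropyl. In a functional assay on PC-3 cells (Homo sapiens) for cytotoxicity, read by WST assay, with a stated time of 3 days (on this read-out lower numbers stand for stronger inhibition and higher numbers for weaker inhibition), compound 1 gives 2800 nM, compound 2 gives 1800 nM, and compound 3 gives 2300 nM. Compound 1 shows the highest of the three numbers, yet all three lie within the usual scatter of one another.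

Compound 4 `CCC(C)n1ccnc1/C=C/C(=O)/C=C/c1coc2ccccc2c1=O` extends the series: sec-butyl in place of methyl on an aromatic nitrogen. Each earlier growth of this group was small in effect: a 1.6-fold lower number from compound 1 to compound 2 (0.19 log units; within the scatter), a 1.2-fold lower number from compound 1 to compound 3 (0.09 log units; within the scatter), and a 1.3-fold higher number from compound 2 to compound 3 (0.11 log units; within the scatter). None of these steps rose above the scatter, so adding one more carbon to reach sec-butyl is expected to do little as well.

Compound 4 is therefore expected to sit near the other three in this assay, with a 1.4-fold lower number from compound 1 to compound 4 (0.15 log units; within the scatter) as the estimated step. The estimated value for compound 4 in this assay is 2000 nM, with a range from 1000 nM to 4500 nM.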

Compound 4, half-maximal inhibitory concentration: 1800 nM
Compound 4: middle estimate off by 1.1-fold (0.05 log units), on the high side; low and high end bracket the measured number.
By their numbers in this assay, from the lowest: compounds 2, 4, 3 and 1 (each within the scatter of the next).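

Enlarging the group on the aromatic nitrogen from methyl to sec-butyl, from 1 heavy atom to 4, still leaves the number in this assay within the scatter, with a 1.6-fold lower number from compound 1 to compound 4 (0.19 log units; within the scatter). Within the data shown here, the closer comparisons read the same way, with a 1.3-fold lower number from compound 3 to compound 4 (0.11 log units; within the scatter) and no change at the digits printed from compound 2 to compound 4 (within the scatter), so across these four saturated groups, branched or not, no step at this position rises above the scatter and size shows no clear trend. Adding a single methyl also gives similar steps in two different settings: the same change on two cores in this assay, a 1.6-fold lower number (0.19 log units; within the scatter) from compound 1 to compound 2 and a 1.3-fold lower number (0.11 log units; within the scatter) from compound 3 to compound 4, 1.2-fold (0.09 log units) apart, within the scatter of two such steps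

All four groups are small saturated carbon groups, so the compounds shown leave open what a longer chain such as n-hexyl, a benzyl group, or a chain ending in an amine or a carboxylic acid would do at this position. They also leave open whether any group on this nitrogen can take the number in this assay beyond the scatter of this narrow band, and whether the same flat picture would hold on other cells.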